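A bulkier amide substituent on the weakest compound

The source may report more compounds than this note shows. Statements on the series, on what has been measured and on what is new or still open speak of the compounds shown alone.

Measured so far:
- compound 1 `CC(=O)N1CC2CNCC2C1`: 23000 nM
- compound 2 `O=C(C1CC1)[C@H]1C[C@@H]2CNC[C@@H](C2)C1`: 1300 nM
- compound 3 `CNC(=O)[C@H]1C[C@@H]2CNC[C@@H](C2)C1`: 100000 nM

In an assay on CHO cells for agonist activity at Neuronal acetylcholine receptor; alpha3/beta4 (Homo sapiens), read by FLIPR and calcium flux (a lower number here means that less compound is needed, a higher number that more compound is needed for the effect), compound 3 gives the highest number of the three; compound 1 sits nearest to it, and compound 2 is furthest away. For the measured compounds named here, the only single-point step measured, a 77-fold higher number from compound 2 to compound 3 (1.89 log units; beyond the scatter), shows how sharply the number rose when methylamino replaced cyclopropyl on the carbonyl carbon. Compound 4 `CC(C)NC(=O)[C@H]1C[C@@H]2CNC[C@@H](C2)C1` keeps the amide and changes only the group on its nitrogen: isopropyl in place of methyl on an amide-type nitrogen. Going by the values given here, no measured step tests this exact exchange, so the expectation rests loosely on compound 3 alone. A modest decrease in this assay is estimated, as a 1.7-fold lower number from compound 3 to compound 4 (0.22 log units; within the scatter), with compound 4 expected to give about 60000 nM, within a range of 15000 nM to 200000 nM.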

Compound 4, half-maximal effective concentration: 27000 nM
Beside the measured number, compound 4's estimate is 2.2-fold (0.35 log units) above it, within the range that was stated.
By their numbers in this assay, from the lowest: compound 2; then compounds 1 and 4 (each within the scatter of the next); then compound 3.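

In this assay the step from methyl to isopropyl on the amide-type nitrogen gives a 3.7-fold lower number from compound 3 to compound 4 (0.57 log units; beyond the scatter) and so shows that the group on this nitrogen can shift the number, with the larger group needing less compound. The change recovers only part of the gap to cyclopropyl on the carbonyl carbon, with a 21-fold higher number from compound 2 to compound 4 (1.32 log units; beyond the scatter) still separating the two. Nothing given here bears on the reason for this result. Going by these compounds, whether a tert-butyl group or a phenyl ring on the same nitrogen would lower the number further remains open.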